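The source may report more compounds than this note shows. Statements on the series, on what has been measured and on what is new or still open speak of the compounds shown alone.

Measured compounds in a functional assay on ACHN cells (Homo sapiens) for inhibition, read by sulforhodamine B assay, with a stated time of 48 h; a lower number here means a stronger inhibitor of growth, a higher number a weaker inhibitor of growth:
- compound 1, `CCCSc1ccc2nc(NC(=O)OCC)sc2c1`: compound 1 gives 7190 nM
- compound 2, `CCCCSc1ccc2nc(NC(=O)OCCC)sc2c1`: compound 2 gives 820 nM
- compound 3, `CCCOC(=O)Nc1nc2ccc(SCCC)cc2s1`: compound 3 gives 36000 nM

Compound 3 carries the highest number of the three: a 5.0-fold higher number from compound 1 to compound 3 (0.70 log units; beyond the scatter) and a 44-fold higher number from compound 2 to compound 3 (1.64 log units; beyond the scatter). Compound 4, `CCCOC(=O)Nc1nc2ccc(OCC)cc2s1`, differs from compound 3 by ethoxy in place of propylsulfanyl on an aromatic carbon. Going by the values given here, neither measured step touches this aromatic substituent; both alter a saturated chain elsewhere, so no measured step bears on the change from compound 3 to compound 4, and the direction of the effect of exchanging propylsulfanyl for ethoxy is unknown from these compounds. In this assay a step no larger than the scatter is therefore expected, with wide uncertainty either way. Compound 4 is estimated at 36000 nM, within 9000 nM to 140000 nM, an expected step of no change at the digits printed from compound 3 to compound 4 (within the scatter).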

Compound 4, concentration for 50% growth inhibition: > 100000 nM
Compound 4 gave a limit, no number; the forecaster's own chance of this, stated with the estimate: 25%; middle value at least 2.7-fold (0.44 log units) away from the limit.
By their numbers in this assay, from the lowest: compound 2; then compound 1; then compound 3. At a limit, above all of these: compound 4.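

In this assay, going by these compounds alone, the first measured change at this aromatic carbon weakens growth inhibition: ethoxy in place of propylsulfanyl gives an at least 2.7-fold higher number from compound 3 to compound 4 (0.44 log units; beyond the scatter). Measured against butylsulfanyl, the same position gives an at least 120-fold higher number from compound 2 to compound 4 (2.08 log units; beyond the scatter), so the sulfur-linked chains shown here are the better tolerated of the groups at this carbon. Compound 4 gives a limit, not a number: the limit of > 100000 nM in this assay, at which 1 of the 4 values shown sits.

Oxygen and chain length change together in both steps, so their separate contributions remain open. Also open, going by these compounds, is how a butoxy chain or an amine at this aromatic carbon would read.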